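Shortening the Decyl Chain of Compound 1

The source may report more compounds than this note shows. Statements on the series, on what has been measured and on what is new or still open speak of the compounds shown alone.

Compound 1 `CCCCCCCCCCc1cc2cn(COCCO)c(O)nc-2n1`: 80000 nM
Compound 2 `CCCCc1cc2cn(COCCO)c(=O)nc2o1`: > 400000 nM, a limit of the assay
Compound 3 `CCCCCc1cc2cn(COCCO)c(=O)nc2o1`: > 400000 nM, a limit of the assay

For the measured compounds named here, in a functional assay on HEL cells (Homo sapiens), read by microscopy (on this read-out higher numbers stand for lower toxicity in this test and lower numbers for higher toxicity in this test), compound 1 gives 80000 nM, the only plain number among the three values shown. Compound 4 `CCCCc1cc2cn(COCCO)c(O)nc-2n1` differs from compound 1 by hydrogen in place of hexyl on a saturated chain carbon, four bonds along the chain from an aromatic carbon. Going by the values given here, the one step measured between two compounds differing in a single place is a step that the two limits leave unreadable from compound 2 to compound 3, so it offers no readable size. Compound 2 and compound 3, each carrying a shorter chain on a different core, both sit at a limit. Compound 4 is therefore expected to shift toward lower toxicity, with a step of a 5.0-fold higher number from compound 1 to compound 4 (0.70 log units; beyond the scatter), because the limit of > 400000 nM in this assay, at which 2 of the 3 values shown sit, is where both shorter-chain compounds stand. The estimate for compound 4 is 400000 nM, between 150000 nM and 1000000 nM, and the assay may again report only a limit.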

Compound 4, minimum cytotoxic concentration: > 400000 nM
Compound 4 was reported as a limit (the forecaster's own chance of this, stated with the estimate: 65%); the middle value lies on the limit itself.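

For the compounds shown here, on the core of compound 1, hydrogen in place of hexyl gives an at least 5.0-fold higher number from compound 1 to compound 4 (0.69 log units; beyond the scatter) in this assay, the first step here with a readable size, and it points toward lower toxicity in this test. Compound 4 gives > 400000 nM, which is a limit of the assay and not a number, so the step's full size stays hidden. The same limit recurs across this small set: the limit of > 400000 nM in this assay, at which 3 of the 4 values shown sit.

Still open, on these data alone, is how a chain of intermediate length on this core would read. As far as these compounds go, a chain ending in an amine is equally open.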